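The source may hold more compounds than are shown below. What is called first, only, known or untested is meant among the compounds shown, and "the series" means these compounds.

Measured so far:
- compound 1 `N[C@@H]1CCCN(C(=O)c2ccc(-c3ccc4ncc(-c5ccc6cnccc6c5)n4c3)cc2)C1`: 7.7 nM
- compound 2 `O=C(c1ccc(-c2ccc3ncc(-c4cnc5ccccc5c4)n3c2)cc1)N1CCOCC1`: 154 nM

In an assay on Sf21 cells for inhibition of MAP kinase-interacting serine/threonine-protein kinase 1 (Homo sapiens), read by luminescence and ADP-Glo, with stated times of 10 min and 40 min (on this read-out lower numbers stand for stronger inhibition and higher numbers for weaker inhibition), compound 1 gives 7.7 nM. In this assay compound 2 gives 154 nM, the highest of the two numbers recorded, and its gap to compound 1 lies well beyond the scatter. For the measured compounds named here, the two compounds differ in more than one place, so no single step between them can be read.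

Compound 3 `O=C(c1ccc(-c2ccc3ncc(-c4ccc5cnccc5c4)n3c2)cc1)N1CCOCC1` is not yet measured. Relative to compound 2 the change is isoquinolin-6-yl in place of quinolin-3-yl on an aromatic carbon. Compound 1 carries the same isoquinolin-6-yl group with a different amide, so the change is only partly backed by shown data. In this assay a step toward a lower number, of moderate size, is expected from compound 2 to compound 3, as a 3.1-fold lower number from compound 2 to compound 3 (0.49 log units; beyond the scatter). Compound 3 is expected to give 50 nM, within 12 nM to 220 nM.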

Compound 3, half-maximal inhibitory concentration: 7 nM
Beside the measured number, compound 3's estimate is 7.1-fold (0.85 log units) above it; measured number below the stated range.
By their numbers in this assay, from the lowest: compounds 3 and 1 (each within the scatter of the next); then compound 2.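

In this assay, with the morpholin-4-yl amide held constant, isoquinolin-6-yl in place of quinolin-3-yl gives a 22-fold lower number from compound 2 to compound 3 (1.34 log units; beyond the scatter), so this position on the five-membered aromatic ring responds strongly to a swap between two groups with the same atom counts. With isoquinolin-6-yl held constant, morpholin-4-yl in place of 3-aminopiperidin-1-yl on the carbonyl carbon gives a 1.1-fold lower number from compound 1 to compound 3 (0.04 log units; within the scatter), so the amine on the piperidine ring is not needed to reach this level of inhibition. Nothing available explains the large step at this position.

On these data alone, whether quinolin-3-yl costs as much when paired with 3-aminopiperidin-1-yl remains open. Also open, as far as these compounds go, is how naphthalen-2-yl, which has carbon-only rings, would read at this position.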